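Tert-butyl for methyl on the ester carbonyl of compound 3

This account rests on a few compounds, and the source may have more. Where it says the series, first, only, none or still open, it means among the compounds named here.

Measured so far in a functional assay on MCF7 cells (Homo sapiens) for cytotoxicity, read by MTT assay; on this read-out lower numbers stand for stronger inhibition and higher numbers for weaker inhibition:
Compound 1 `CC(=O)O[C@@H]1OC(=O)[C@](C)(C(C)=O)[C@@H]1C` gives 6000 nM.
Compound 2 `CC(=O)[C@@]1(C)C(=O)O[C@@H](OC(=O)C(C)(C)C)[C@H]1C` gives 3000 nM.
Compound 3 `CC(=O)O[C@@H]1OC(=O)[C@@](C)(C(C)=O)[C@@H]1C` gives > 10000 nM, a limit of the assay and not a number.

Compound 3 thus stands only at a limit; its position relative to compound 1 is known just as an at least 1.6-fold higher number from compound 1 to compound 3 (0.22 log units; that floor lies within the scatter). Compound 4 `CC(=O)[C@]1(C)C(=O)O[C@@H](OC(=O)C(C)(C)C)[C@H]1C` carries tert-butyl in place of methyl on a carbonyl carbon. Among the measured compounds shown here, the one measured step of this kind is a 2.0-fold lower number from compound 1 to compound 2 (0.30 log units; within the scatter), within the scatter. The expected step is therefore a number no higher from compound 3 to compound 4 (the limit leaves the size open), none beyond the scatter, and compound 4 will most likely again return only a limit. Compound 4 is estimated at 10000 nM, within 4000 nM to 30000 nM.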

Compound 4, half-maximal inhibitory concentration: 7000 nM
Beside the measured number, compound 4's estimate is 1.4-fold (0.15 log units) above it, and the stated range covers the measured number.
By their numbers in this assay, from the lowest: compounds 2, 1 and 4 (each within the scatter of the next, the first and the last beyond it). At a limit, above all of these: compound 3.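

In this assay, compound 4 returns a number where compound 3 gave only a limit, so tert-butyl in place of methyl on a carbonyl carbon now has a reading on this configuration too, with an at least 1.4-fold lower number from compound 3 to compound 4 (0.15 log units; that floor lies within the scatter). The configuration at the saturated ring carbon also gains its first step beyond the scatter, a 2.3-fold higher number from compound 2 to compound 4 (0.37 log units; beyond the scatter), a modest one: the fact that compounds 2 and 4 differ only in the configuration as drawn.

Whether the change has the same size on both configurations remains unsettled: the same change on two cores in this assay, a 2.0-fold lower number (0.30 log units; within the scatter) from compound 1 to compound 2 and an at least 1.4-fold lower number (0.15 log units; that floor lies within the scatter) from compound 3 to compound 4; the limit leaves it open whether they differ. Also open, from the compounds shown here alone, is whether an amine or a longer chain in place of tert-butyl on that carbonyl carbon would move the number beyond the scatter.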